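Swapping the aryl group on the sulfonyl sulfur

The source may hold more compounds than are shown below. What is called first, only, known or untested is meant among the compounds shown, and "the series" means these compounds.

Among the compounds with values here, compound 2 `COc1ccc(S(=O)(=O)NC(C)C2=CC(=O)c3c(O)ccc(O)c3C2=O)c(OC)c1` gives 19500 nM in a functional assay on HeLa cells (Homo sapiens) for cytotoxicity, read by sulforhodamine B assay (on this read-out higher numbers stand for weaker inhibition and lower numbers for stronger inhibition), the highest of the two numbers measured so far; compound 1 `COc1ccc(S(=O)(=O)NC(C2=CC(=O)c3c(O)ccc(O)c3C2=O)C(C)C)c(OC)c1` gives 2750 nM, and the step of a 7.1-fold higher number from compound 1 to compound 2 (0.85 log units; beyond the scatter) separates them. Compound 3 `CC(=O)c1ccc(S(=O)(=O)NC(C)C2=CC(=O)c3c(O)ccc(O)c3C2=O)cc1` differs from compound 2 in one place: 4-acetylphenyl in place of 2,4-dimethoxyphenyl on a sulfonyl sulfur. Within the data shown here, the only measured step concerns the saturated chain carbon, not the sulfonyl sulfur, so no measured step bears on this change. The expected step is therefore a 1.3-fold lower number from compound 2 to compound 3 (0.11 log units; within the scatter), nothing beyond the scatter, with wide uncertainty. Compound 3 is estimated at 15000 nM, between 4000 nM and 60000 nM.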

Compound 3, half-maximal inhibitory concentration: 5760 nM
Compound 3: the middle estimate sits 2.6-fold (0.42 log units) above what was measured; low and high end bracket the measured number.
By their numbers in this assay, from the lowest: compound 1; then compound 3; then compound 2.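

Within the data shown here, the aryl group on the sulfonyl sulfur proves to be a second place where the number moves in this assay: 4-acetylphenyl in place of 2,4-dimethoxyphenyl gives a 3.4-fold lower number from compound 2 to compound 3 (0.53 log units; beyond the scatter) at a position no earlier step had touched. Nothing measured here accounts for this step.

The compounds shown leave open whether the step follows from the leaving methoxy groups or from the entering acetyl, and whether isopropyl on the chain carbon would add to it. Going by these compounds, how an amine or a carboxylic acid on that aromatic ring would read also stays open.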